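A few compounds are considered here, and "the series" means these few. Any claim that something is new, unique, unknown or untested is made for them only; others in the source may bear on it.

In a functional assay on MCF7 cells (Homo sapiens) for cytotoxicity, read by MTT assay, with a stated time of 48 h (on this read-out lower numbers stand for stronger inhibition and higher numbers for weaker inhibition), three compounds built on one shared core have been measured. Compound 1 `COc1ccc(N/C(CCNC2=CC(=O)c3ccccc3C2=O)=N\S(=O)(=O)c2ccc(C)cc2)cc1` gives 6030 nM. Compound 2 `Cc1ccc(S(=O)(=O)/N=C(/CCNC2=CC(=O)c3ccccc3C2=O)Nc2cccc(C)c2)cc1` gives 8120 nM. Compound 3 `COc1ccc(N/C(CCNC2=CC(=O)c3ccccc3C2=O)=N\S(=O)(=O)c2ccc(C)cc2)c(OC)c1` gives 30200 nM, the highest of the three numbers and so the weakest inhibitor here: the steps of a 5.0-fold higher number from compound 1 to compound 3 (0.70 log units; beyond the scatter) and a 3.7-fold higher number from compound 2 to compound 3 (0.57 log units; beyond the scatter) both lie beyond the scatter, while a 1.3-fold higher number from compound 1 to compound 2 (0.13 log units; within the scatter) does not.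

Compound 4 `Cc1ccc(S(=O)(=O)/N=C(/CCNC2=CC(=O)c3ccccc3C2=O)NC(C)C)cc1` differs from compound 3 in one place: isopropyl in place of 2,4-dimethoxyphenyl on an amine nitrogen. Among the measured compounds shown here, no measured step removes the aromatic ring from this amine nitrogen, so the earlier steps bear on the change only loosely. As far as these compounds go, the steps of a 5.0-fold higher number from compound 1 to compound 3 (0.70 log units; beyond the scatter) and a 3.7-fold higher number from compound 2 to compound 3 (0.57 log units; beyond the scatter) show that the 2,4-dimethoxyphenyl group accompanies the highest number seen, so taking it away might bring the number back toward those of compound 1 and compound 2; yet an isopropyl group at this position is untested. The step of a 2.5-fold lower number from compound 3 to compound 4 (0.40 log units; beyond the scatter) is therefore expected to be a modest fall in the number, with wide uncertainty either way. Compound 4 is estimated at 12000 nM, likely between 3000 nM and 50000 nM.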

Compound 4, half-maximal inhibitory concentration: 16500 nM
Beside the measured number, compound 4's estimate is 1.4-fold (0.14 log units) below it; the measured number falls inside the stated range.
By their numbers in this assay, from the lowest: compounds 1 and 2 (each within the scatter of the next); then compounds 4 and 3 (each within the scatter of the next).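

Replacing the 2,4-dimethoxyphenyl group with isopropyl removes the aromatic ring from this amine nitrogen, yet it gives only a 1.8-fold lower number from compound 3 to compound 4 (0.26 log units; within the scatter), so in this assay a ring at this position is not needed to reach the level of compound 3. The ring can still matter, depending on what it carries: isopropyl in place of 3-methylphenyl gives a 2.0-fold higher number from compound 2 to compound 4 (0.31 log units; beyond the scatter), and isopropyl in place of 4-methoxyphenyl gives a 2.7-fold higher number from compound 1 to compound 4 (0.44 log units; beyond the scatter), both modest steps. The data offer no explanation for these differences.

As far as these compounds go, it remains open whether an unsubstituted phenyl ring at this nitrogen would behave like 3-methylphenyl and 4-methoxyphenyl or like 2,4-dimethoxyphenyl. Equally open, from the compounds shown here alone, is how a non-aromatic ring such as cyclohexyl, or a longer chain such as n-butyl, would compare with isopropyl.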